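From 3-chlorophenyl to 2-fluorophenyl on a shared core

A few compounds are considered here, and "the series" means these few. Any claim that something is new, unique, unknown or untested is made for them only; others in the source may bear on it.

Measured so far in a functional assay on MDA-MB-231 cells (Homo sapiens) for antiproliferative activity, read by MTT assay, with a stated time of 24 h; a higher number here means a weaker inhibitor, a lower number a stronger inhibitor:
compound 1 `Cc1ccc(C(=O)NNC(=O)c2ccccc2NS(=O)(=O)c2cnc(O)nc2O)cc1`: > 20000 nM (a limit)
compound 2 `O=C(NNC(=O)c1ccccc1NS(=O)(=O)c1cnc(O)nc1O)c1ccccc1Cl`: 8310 nM
compound 3 `O=C(NNC(=O)c1ccccc1NS(=O)(=O)c1cnc(O)nc1O)c1cccc(Cl)c1`: 4420 nM

These compounds share one core and differ only in the group on a carbonyl carbon. The entry for compound 1, > 20000 nM, is a limit of the assay and not a number. Only compound 2 and compound 3 therefore have true numbers, and a 1.9-fold lower number from compound 2 to compound 3 (0.27 log units; within the scatter) places those two within the scatter of each other. Both steps that start at the limit, an at least 2.4-fold lower number from compound 1 to compound 2 (0.38 log units; beyond the scatter) and an at least 4.5-fold lower number from compound 1 to compound 3 (0.65 log units; beyond the scatter), go beyond the scatter.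

Compound 4 `O=C(NNC(=O)c1ccccc1NS(=O)(=O)c1cnc(O)nc1O)c1ccccc1F` has not yet been measured in this assay. Going from compound 3, the change is 2-fluorophenyl in place of 3-chlorophenyl on a carbonyl carbon. Going by the values given here, no measured compound carries fluorine, so the closest guide is compound 2, with its 2-chlorophenyl group, at 8310 nM. Among the compounds with values here, the only step between two true numbers, a 1.9-fold lower number from compound 2 to compound 3 (0.27 log units; within the scatter), stays within the scatter, so only a small step is expected here, leaning toward a higher number. The estimate means a 1.8-fold higher number from compound 3 to compound 4 (0.26 log units; within the scatter), an expected change of about the size of the scatter. Compound 4 is expected at about 8000 nM, with an estimated range of 3500 nM to 18000 nM.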

Compound 4, half-maximal inhibitory concentration: > 20000 nM
Compound 4 gave a limit, no number (the forecaster's own chance of this, stated with the estimate: 20%); at least 2.5-fold (0.39 log units) between middle value and limit.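

Fluoro in place of chloro on an aromatic carbon is the smallest change in this set, yet it gives an at least 2.4-fold higher number from compound 2 to compound 4 (0.38 log units; beyond the scatter), so the halogen on this phenyl group matters and chloro cannot be swapped for fluoro without a loss in this test. The earlier chlorophenyl compounds, compound 2 and compound 3, stayed within the scatter of each other, whereas changing 3-chlorophenyl to 2-fluorophenyl gives an at least 4.5-fold higher number from compound 3 to compound 4 (0.65 log units; beyond the scatter), and both steps give only a smallest possible size. The step that joins compound 1 and compound 4 cannot be read, and neither compound has a true number, only a limit of the assay: the limit of > 20000 nM in this assay, at which 2 of the 4 values shown sit.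

Going by these compounds, how far compound 4 lies beyond its limit remains open, so the real size of both steps is unknown. Also open, on these data alone, is what a 3-fluorophenyl, 3-bromophenyl or 3-methoxyphenyl group on the same carbonyl carbon would give, which would help separate the effect of the halogen from the effect of where it sits.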